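A few compounds are considered here, and "the series" means these few. Any claim that something is new, unique, unknown or untested is made for them only; others in the source may bear on it.

Measured so far in an in vitro ADME assay on microsomes from liver (Homo sapiens) for metabolic stability; on this read-out lower numbers stand for a shorter-lived compound and higher numbers for a longer-lived compound:
- compound 1 `COc1ccc(-c2cc(-c3cccc(S(C)(=O)=O)c3)cnc2N)cn1`: 3.78 h
- compound 2 `CNS(=O)(=O)c1ccc(-c2cnc(N)c(-c3ccc(OC)nc3)c2)cc1`: 3.02 h
- compound 3 `COc1ccc(-c2cnc(N)c(-c3ccc(OC)nc3)c2)cn1`: 1.45 h

Compound 2 stands second highest of the three numbers in this assay. Its nearest neighbour is compound 1, whose value lies within the scatter of that of compound 2, so no order can be read between these two. Compound 3 sits furthest away, with a value beyond the scatter below that of compound 2; the two numbers show compound 3 as the shorter-lived of this pair. For the measured compounds named here, no pair of measured compounds differing in a single place exists in the set, so there is no direct precedent for the change considered here.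

Compound 4 `COc1ccc(-c2cc(-c3ccc(-n4cncn4)cc3)cnc2N)cn1` is not yet measured. It differs from compound 2 in one place: 1H-1,2,4-triazol-1-yl in place of methylsulfamoyl on an aromatic carbon. The three measured values cover a narrow span, and none of them isolates the group that changes. The step expected in this assay is therefore small, a 1.2-fold lower number from compound 2 to compound 4 (0.08 log units; within the scatter), with no direction beyond the scatter asserted. Compound 4 is estimated at 2.5 h in this assay, within an expected range from 1.2 h to 5 h.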

Compound 4, half-life: 3.5 h
Beside the measured number, compound 4's estimate is 1.4-fold (0.15 log units) below it, within the range that was stated.
By their numbers in this assay, from the lowest: compound 3; then compounds 2, 4 and 1 (each within the scatter of the next).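

In this assay, for the compounds shown here, the first comparison in one place gives a 1.2-fold higher number from compound 2 to compound 4 (0.06 log units; within the scatter) for 1H-1,2,4-triazol-1-yl in place of methylsulfamoyl on an aromatic carbon, para to a large group, so this exchange produces no readable change in half-life. At this position, a group with no ring, a hydrogen-bond donor and two double bonds outside aromatic rings gives way to a five-membered aromatic ring with 3 hetero atoms and no hydrogen-bond donor, and the step stays within the scatter. No measurement offered here accounts for this result.

This single pair cannot separate the loss of the hydrogen-bond donor from the arrival of the ring, nor show whether the exchange would read the same on another core. Also open, from the compounds shown here alone, is how other groups at this position, such as a carboxylic acid, a primary amine or a methoxy group, would stand in this assay against methylsulfamoyl and 1H-1,2,4-triazol-1-yl.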